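A few compounds are considered here, and "the series" means these few. Any claim that something is new, unique, unknown or untested is made for them only; others in the source may bear on it.

Measured compounds in a functional assay on PC-3 cells (Homo sapiens) for cytotoxicity, read by MTT assay, with a stated time of 72 h; on this read-out higher numbers stand for weaker inhibition of growth and lower numbers for stronger inhibition of growth:
- compound 1 `O=C(/N=C(/NC(=O)c1csc([N+](=O)[O-])c1)[Se]Cc1ccccc1)c1csc([N+](=O)[O-])c1`: 69200 nM
- compound 2 `C[Se]/C(=N\C(=O)c1cnc2ccccc2c1)NC(=O)c1cnc2ccccc2c1`: 43600 nM

Two compounds carry numbers in this assay. Compound 2 stands at the lower of the two numbers, but the gap to compound 1 lies within the usual scatter, so the two cannot be told apart on these data; no order of growth inhibition is read from them. Among the compounds with values here, no pair differing in a single place has been measured, so no step size is known for this series.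

Compound 3 `CS/C(=N\C(=O)c1cnc2ccccc2c1)NC(=O)c1cnc2ccccc2c1` shares the core of compound 2 and differs from it only in one place: a group of 2 heavy atoms (1 carbon, 1 sulfur; no ring) in place of a group of 2 heavy atoms (1 carbon, 1 selenium; no ring), on a carbon with a double bond to nitrogen. Nothing measured here shows what an exchange of this kind does in this assay. Within the data shown here, with no step to lean on, the expectation for compound 3 is a number close to that of compound 2, with no shift beyond the scatter in either direction; the step from compound 2 to compound 3 is therefore expected to be about a 1.1-fold higher number from compound 2 to compound 3 (0.06 log units; within the scatter). For compound 3 in this assay the estimate is 50000 nM, with a range from 20000 nM to 130000 nM.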

Compound 3, concentration for total growth inhibition: > 100000 nM
Compound 3: no number, only a limit (the forecaster's own chance of this, stated with the estimate: 10%); at least 2.0-fold (0.30 log units) between middle value and limit.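

In this assay, the series now has its first comparison of compounds that differ in one place: methylsulfanyl in place of the group carrying selenium, on a carbon with a double bond to nitrogen, gives an at least 2.2-fold higher number from compound 2 to compound 3 (0.36 log units; beyond the scatter). This shows that, with the rest of the core of compound 2 unchanged, growth inhibition in this read-out responds to the exchange of selenium for sulfur at this position, and that the selenium-bearing compound 2 is the stronger of the pair. Compound 3 carries > 100000 nM, which is a limit of the assay and not a number, so the full size of the step remains unknown because of where compound 3 sits: the limit of > 100000 nM in this assay, at which 1 of the 3 values shown sits.

On these data alone, whether the same exchange moves the number in the same direction on the core of compound 1 remains open, since a single pair cannot establish a pattern. Also open, as far as these compounds go, is what a methoxy group, with oxygen in place of sulfur, a longer chain such as ethylsulfanyl, or an amine on the same carbon would do in this assay.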